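The source may report more compounds than this note shows. Statements on the series, on what has been measured and on what is new or still open speak of the compounds shown alone.

Compound 1 `Fc1ccc(C2=NN(C3=NC(c4ccccc4)CS3)C(c3cccc4ccccc34)C2)cc1` gives 23200 nM in a functional assay on HepG2 cells (Homo sapiens) for inhibition, read by CCK-8 assay, with a stated time of 48 h (a lower number here means a stronger inhibitor, a higher number a weaker inhibitor), the upper of the two numbers shown, though within the scatter of compound 2 `O=C1CSC(N2N=C(c3ccc(F)cc3)CC2c2cccc3ccccc23)=N1`, which gives 19500 nM in this assay. For the measured compounds named here, the one measured step, a 1.2-fold lower number from compound 1 to compound 2 (0.08 log units; within the scatter), changes a group on an amine nitrogen in a ring, so it does not test the change that leads to compound 3 `Brc1ccc(C2=NN(C3=NC(c4ccccc4)CS3)C(c3cccc4ccccc34)C2)cc1`, namely (bromo in place of fluoro on an aromatic carbon). Going by the values given here, no halogen swap has been measured, and the only known step stays within the scatter, so no movement beyond the scatter is expected. The expected step is a 1.2-fold lower number from compound 1 to compound 3 (0.06 log units; within the scatter). Compound 3 is estimated at 20000 nM, with a range from 7000 nM to 55000 nM.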

Compound 3, half-maximal inhibitory concentration: 15600 nM
Compound 3: the middle estimate sits 1.3-fold (0.11 log units) above what was measured; the measured number falls inside the stated range.
By their numbers in this assay, from the lowest: compounds 3, 2 and 1 (each within the scatter of the next).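

Placed para to a large group, bromo in place of fluoro gives a 1.5-fold lower number from compound 1 to compound 3 (0.17 log units; within the scatter) in this assay. For the compounds shown here, this is the first halogen swap, and it shows that 4-fluorophenyl and 4-bromophenyl cannot be told apart at this position in this assay. Nothing available here explains this result.
From the compounds shown here alone, whether an amine, a methoxy group or a carboxylic acid at this position would move the number beyond the scatter remains open. Also open, going by these compounds, is whether the same halogen swap would read alike on the core of compound 2.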